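Chain extension at the aromatic nitrogen: compound 3 to compound 4

A few compounds are considered here, and "the series" means these few. Any claim that something is new, unique, unknown or untested is made for them only; others in the source may bear on it.

Compound 1 `COc1ccc(Cn2c(SCc3cc([N+](=O)[O-])cc([N+](=O)[O-])c3)nnc2-c2ccccc2)cc1` is tested in an ADME assay on A-431 cells (Homo sapiens) for cytotoxicity, with a stated time of 48 h; a higher number here means a weaker inhibitor, a lower number a stronger inhibitor; there compound 1 gives > 30000 nM, a limit of the assay and not a number. Compound 2 `Cn1c(SCc2ccccc2)nnc1-c1cc([N+](=O)[O-])cc([N+](=O)[O-])c1` gives > 30000 nM in this assay, again only a limit. Compound 3 `CCn1c(SCc2ccccc2)nnc1-c1cc([N+](=O)[O-])cc([N+](=O)[O-])c1` gives > 30000 nM in this assay, also a limit. The step that the two limits leave unreadable from compound 2 to compound 3 is therefore unreadable, and what the series offers is the limit of > 30000 nM in this assay, at which 3 of the 3 values shown sit. Compound 4 `CCCCCCn1c(SCc2ccccc2)nnc1-c1cc([N+](=O)[O-])cc([N+](=O)[O-])c1` differs from compound 3 by butyl in place of hydrogen on a saturated chain carbon, two bonds along the chain from an aromatic nitrogen. For the measured compounds named here, no measured step bears on this change with a readable size, so for compound 4 a step that the limit leaves unreadable from compound 3 to compound 4 of no size beyond the scatter is expected, and compound 4 is expected to give 50000 nM in this assay, within 15000 nM to 150000 nM, most likely again reported only as a limit.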

Compound 4, half-maximal inhibitory concentration: > 30000 nM
Compound 4 ended at the assay's limit; the forecaster's own chance of this, stated with the estimate: 85%; the middle value does not contradict the limit.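

In this assay compound 4 gives > 30000 nM, again a limit of the assay. For the compounds shown here, no step among compound 2, compound 3 and compound 4 can be read: the limit of > 30000 nM in this assay, at which 4 of the 4 values shown sit. From the compounds shown here alone, whether chain length on the aromatic nitrogen changes this read-out at all remains open, as does the actual half-maximal inhibitory concentration of each compound.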